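This account rests on a few compounds, and the source may have more. Where it says the series, first, only, none or still open, it means among the compounds named here.

Compound 1 `O=C(NN=C(c1ccccn1)c1ccccn1)c1cccs1` is the stronger of the two compounds measured in an ADME assay on cells (Homo sapiens) for antiproliferative activity, read by MTT assay; a higher number here means a weaker inhibitor, a lower number a stronger inhibitor: in this assay compound 1 gives 950 nM, while compound 2 `O=C(N/N=C/c1ccccn1)c1cccc(Br)c1`, which shares the 3-bromophenyl group on its carbonyl carbon but not the rest of the core, gives 13500 nM, a gap that lies well beyond the usual scatter. Compound 3 `O=C(NN=C(c1ccccn1)c1ccccn1)c1cccc(Br)c1` keeps the core of compound 1 and carries one change: 3-bromophenyl in place of thiophen-2-yl on a carbonyl carbon. Among the compounds with values here, no pair of measured compounds isolates this swap, so its effect is open. Since compound 2 with 3-bromophenyl on the carbonyl gives 13500 nM in this assay, a modest weakening is expected for compound 3, with the step from compound 1 to compound 3 estimated at a 2.1-fold higher number from compound 1 to compound 3 (0.32 log units; beyond the scatter). Compound 3 is therefore expected to give about 2000 nM in this assay, most likely between 700 nM and 6000 nM.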

Compound 3, half-maximal inhibitory concentration: 240 nM
Compound 3: the middle estimate sits 8.3-fold (0.92 log units) above what was measured, and the stated range ends above it.
By their numbers in this assay, from the lowest: compound 3; then compound 1; then compound 2.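

On the core of compound 1, the carbonyl carbon accepts the larger 3-bromophenyl group in place of thiophen-2-yl, and this assay shows a 4.0-fold lower number from compound 1 to compound 3 (0.60 log units; beyond the scatter). Within the data shown here, this is the first reading of this swap, and it runs in the direction of a stronger inhibitor. Compound 2 carries the same 3-bromophenyl group and gives 13500 nM, whereas compound 3 gives 240 nM, so a high number does not follow from that group on every core shown. Nothing measured here accounts for the step. The compounds shown leave open whether the step belongs to the bromine or to the six-membered ring, which a plain phenyl group on the same carbonyl carbon would separate, and how an amine or a carboxylic acid on that ring would read.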